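This account rests on a few compounds, and the source may have more. Where it says the series, first, only, none or still open, it means among the compounds named here.

In an ADME assay on Vero cells (Chlorocebus sabaeus) for antiproliferative activity, read by MTT assay, with a stated time of 72 h (on this read-out higher numbers stand for weaker inhibition and lower numbers for stronger inhibition), compound 1 `Cc1ccc(N(C)S(=O)(=O)C2CC3OC2C(c2ccc(NC(=O)CCCCCCC(=O)O)cc2)=C3c2ccc(O)cc2)cc1` gives > 100000 nM, which is a limit of the assay and not a number. Compound 2 `Cc1cccc(N(C)S(=O)(=O)C2CC3OC2C(c2ccc(NC(=O)CCCCCCC(=O)O)cc2)=C3c2ccc(O)cc2)c1` gives > 100000 nM, again a limit. Compound 3 `CCN(c1ccc(OC)cc1)S(=O)(=O)C1CC2OC1C(c1ccc(NC(=O)CCCCCCC(=O)O)cc1)=C2c1ccc(O)cc1` gives > 100000 nM, also a limit. Compound 3 therefore stands level with the other two, at the limit of > 100000 nM in this assay, at which 3 of the 3 values shown sit.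

Compound 4 `CCN(c1cccc(OC)c1)S(=O)(=O)C1CC2OC1C(c1ccc(NC(=O)CCCCCCC(=O)O)cc1)=C2c1ccc(O)cc1` differs from compound 3 in one group: 3-methoxyphenyl in place of 4-methoxyphenyl on a sulfonamide nitrogen. In words, this is 3-methoxyphenyl in place of 4-methoxyphenyl on a sulfonamide nitrogen. The closest measured parallel is a step that the two limits leave unreadable from compound 1 to compound 2, where 3-methylphenyl replaces 4-methylphenyl at the same kind of nitrogen. That step has no readable size, so it shows neither a gain nor a loss from such a move, yet neither member of the pair left the limit. The expected change, a step that the limit leaves unreadable from compound 3 to compound 4, is therefore none beyond the usual scatter, in either direction. In this assay the estimate for compound 4 is 150000 nM, with an expected range of 70000 nM to 300000 nM, and the result will most likely be only a limit again.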

Compound 4, half-maximal inhibitory concentration: > 100000 nM
Compound 4: no number, only a limit (the forecaster's own chance of this, stated with the estimate: 90%); the middle value lies beyond the limit too.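

Compound 4 also sits at a limit, so no step from compound 1, compound 2 or compound 3 to compound 4 can be read: the limit of > 100000 nM in this assay, at which 4 of the 4 values shown sit.

The compounds shown leave open how strongly any of them acts in this assay, and whether these group changes alter that at all.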